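A few compounds are considered here, and "the series" means these few. Any claim that something is new, unique, unknown or untested is made for them only; others in the source may bear on it.

Working notes on the series. The shared core is the piperazine carbodithioate bearing a triazolylmethyl arm, as in compound 1 `CCN(C)C(=O)N1CCN(C(=S)SCc2cn(Cc3ccccc3F)nn2)CC1`, and the measured compounds differ at the urea nitrogen. In a functional assay on EC9706 cells (Homo sapiens) for cytotoxicity, read by MTT assay, with a stated time of 72 h (a higher number here means a weaker inhibitor, a lower number a stronger inhibitor), compound 1 gives 15600 nM. Compound 2 `CC(C)(C)NC(=O)N1CCN(C(=S)SCc2cn(Cc3ccccc3F)nn2)CC1` carries a tert-butylamino group on the carbonyl carbon, and in this assay compound 2 gives 87800 nM. The step of a 5.6-fold higher number from compound 1 to compound 2 (0.75 log units; beyond the scatter) shows that the amine on the urea carbonyl moves the number well beyond the scatter. Within the data shown here, compound 1 thus stands as the lowest of the two numbers known so far.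

Compound 3 `CCN(C)C(=O)N1CCN(C(=S)SCc2cn(Cc3ccc(OC)cc3)nn2)CC1` keeps the ethyl(methyl)amino urea of compound 1 and changes only the benzyl arm: 4-methoxyphenyl in place of 2-fluorophenyl on a saturated chain carbon bound to an aromatic nitrogen. Among the measured compounds shown here, no measured step touches this position; the single step known, from the urea amine, says nothing about the benzyl substituent. With no comparable change in hand, the expectation for this assay is a step of a 1.0-fold lower number from compound 1 to compound 3 (0.02 log units; within the scatter) of uncertain direction and probably within the scatter, though a change of this kind could well exceed it. Compound 3 is therefore estimated at 15000 nM, with a range from 5000 nM to 50000 nM.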

Compound 3, half-maximal inhibitory concentration: > 128000 nM
Compound 3 gave a limit, no number; the forecaster's own chance of this, stated with the estimate: 10%; at least 8.5-fold (0.93 log units) between middle value and limit.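

In this assay, with the ethyl(methyl)amino urea held fixed, the change from 2-fluorobenzyl to 4-methoxybenzyl gives an at least 8.2-fold higher number from compound 1 to compound 3 (0.91 log units; beyond the scatter). The earlier compounds shown here showed only that the amine on the urea carbonyl moves the number; this step shows that the benzyl arm moves it as well, and that the arm matters at least as a second point of change, with the number again going up from compound 1. Compound 3 stands as a limit of the assay and not a number, so the step fixes only a lower bound on its size: the limit of > 128000 nM in this assay, at which 1 of the 3 values shown sits.

The compounds shown leave open whether the higher number goes with the loss of the 2-fluoro substituent or with the gain of the 4-methoxy substituent, since this one step changes both at once. Going by these compounds, an unsubstituted benzyl or a 4-fluorobenzyl group on the urea of compound 1 would bear on that question, and how far the arm tolerates any other substituent, such as a 4-chlorobenzyl group, also remains unknown.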